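Swapping the pyridine for a pyrimidine on the ether arm

A few compounds are considered here, and "the series" means these few. Any claim that something is new, unique, unknown or untested is made for them only; others in the source may bear on it.

Within the data shown here, compound 2 `Cc1c(C2CC2)nc2ccc(-n3ccc(OCc4ccccn4)cc3=O)cn12` gives 240 nM in an assay on CHO cells for displacement of a labelled ligand from melanin-concentrating hormone receptor 1 (Homo sapiens), read by scintillation counting, with a stated time of 1 h (a higher number here means a weaker inhibitor, a lower number a stronger inhibitor), the higher of the two numbers so far, since compound 1 `Cc1c(C2CC2)nc2ccc(-n3ccc(OCc4ccc(F)cc4)cc3=O)cn12` gives 47 nM. Compound 3 `Cc1c(C2CC2)nc2ccc(-n3ccc(OCc4cncnc4)cc3=O)cn12` differs from compound 2 in one place: pyrimidin-5-yl in place of pyridin-2-yl on a saturated chain carbon bound to an oxygen on an aromatic ring. Among the measured compounds shown here, only one earlier step touches this position, a 5.1-fold higher number from compound 1 to compound 2 (0.71 log units; beyond the scatter), and it shows that changing the ring there can move the number beyond the scatter. Because a 5.1-fold higher number from compound 1 to compound 2 (0.71 log units; beyond the scatter) went upward, a further upward step is expected here, estimated as a 1.9-fold higher number from compound 2 to compound 3 (0.27 log units; within the scatter). Compound 3 is therefore expected at about 450 nM, within 120 nM to 1700 nM.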

Compound 3, half-maximal inhibitory concentration: > 1000 nM
Compound 3 was reported as a limit; the forecaster's own chance of this, stated with the estimate: 5%; at least 2.2-fold (0.34 log units) between middle value and limit.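

Compound 3 is reported only as a limit, not as a number: the limit of > 1000 nM in this assay, at which 1 of the 3 values shown sits.

Even so, the direction is clear. Pyrimidin-5-yl on this saturated chain carbon gives an at least 4.1-fold higher number from compound 2 to compound 3 (0.61 log units; beyond the scatter), and against the 4-fluorophenyl ether it gives an at least 21-fold higher number from compound 1 to compound 3 (1.32 log units; beyond the scatter), which makes compound 3 the weakest of the three.

This change alters both the count of hetero atoms and where the ring is attached, and the compounds shown cannot separate the two. A pyridin-3-yl or pyridin-4-yl ring on the same carbon could tell them apart, and a plain phenyl would show what the fluorine contributes.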